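Shifting Both Chlorines on the Ring-Nitrogen Aryl Group

A few compounds are considered here, and "the series" means these few. Any claim that something is new, unique, unknown or untested is made for them only; others in the source may bear on it.

Compound 3 `Nc1scc(CN2CCN(c3cccc(Cl)c3Cl)CC2)c1C(=O)c1ccc(Cl)cc1` shows the lowest number of the three compounds measured: in a functional assay on CHO cells with adenosine receptor A1 (Homo sapiens) as the target, read by cAMP accumulation and immunoassay, with a stated time of 6 min, tested at 10 uM (a lower number here means a stronger effect, a higher number a weaker effect of the compound at the concentration tested), compound 3 gives -77%. Compound 2 `Nc1scc(CN2CCN(c3ccc(Cl)cc3Cl)CC2)c1C(=O)c1ccc(Cl)cc1` gives -74%, and the step of a number 3 percentage points lower from compound 2 to compound 3 (within the scatter) lies within the scatter, so the two cannot be told apart. Compound 1 `CC(C)N1CCN(Cc2csc(N)c2C(=O)c2ccc(Cl)cc2)CC1`, which carries isopropyl instead of a dichlorophenyl, gives -7.4%; the steps of a number 66.6 percentage points lower from compound 1 to compound 2 (beyond the scatter) and a number 69.6 percentage points lower from compound 1 to compound 3 (beyond the scatter) are large. Compound 4 `Nc1scc(CN2CCN(c3cc(Cl)cc(Cl)c3)CC2)c1C(=O)c1ccc(Cl)cc1` differs from compound 3 in one place: 3,5-dichlorophenyl in place of 2,3-dichlorophenyl on an amine nitrogen in a ring. For the measured compounds named here, the only measured step that bears on this change, the swap of one dichlorophenyl for another from compound 2 to compound 3, stayed within the scatter. The step to compound 4 is therefore expected to be a number 7 percentage points higher from compound 3 to compound 4 (within the scatter). Compound 4 is estimated at -70%, between -90% and -40%.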

Compound 4, a percentage reported as activity, at one concentration (the size of the read-out at that concentration, not a potency): -74%
The estimate for compound 4 lay 4 percentage points above the measured number, and the stated range covers the measured number.
By their numbers in this assay, from the lowest: compounds 3, 2 and 4 (each within the scatter of the next); then compound 1.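

In this assay, a third placement of the two chlorines, 3,5-dichlorophenyl, again makes no difference beyond the scatter (a number 3 percentage points higher from compound 3 to compound 4 (within the scatter)) (no change at the digits printed from compound 2 to compound 4 (within the scatter)). All three dichlorophenyl compounds stay far from the isopropyl compound (a number 66.6 percentage points lower from compound 1 to compound 4 (beyond the scatter)), so among these compounds, having a dichlorophenyl on the amine nitrogen matters more than where its chlorines sit. Nothing available explains why this placement makes so little difference. Still open, on these data alone, is whether the chlorines are needed at all: a plain phenyl, a single-chlorine phenyl or a methoxyphenyl could answer that.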